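The source may report more compounds than this note shows. Statements on the series, on what has been measured and on what is new or still open speak of the compounds shown alone.

Measured compounds:
- compound 1, `COc1ccc(-c2ccc(COCCCCCN3C[C@H](O)[C@@H](O)[C@H](O)[C@H]3CO)cc2)cc1`, which in an assay on isolated protein for inhibition of Beta-glucosidase (Homo sapiens) (a higher number here means a weaker inhibitor, a lower number a stronger inhibitor), gives 10 nM
- compound 2, `OC[C@@H]1[C@@H](O)[C@H](O)[C@@H](O)CN1CCCCCOCc1ccc(-c2ccccc2)c(C(F)(F)F)c1`, which in this assay gives 0.08 nM

Compound 2 has the lower of the two numbers obtained in this assay, and its separation from compound 1 lies beyond the usual scatter, so it is the stronger inhibitor of the two. The piece now follows the step from compound 2 to compound 3, the unmeasured compound `OC[C@H]1[C@@H](O)[C@H](O)[C@@H](O)CN1CCCCCOCc1ccc(-c2ccccc2)c(C(F)(F)F)c1`. The change is purely one of configuration: the two compounds have the same atoms and bonds and differ only in configuration as drawn: 1 of 4 stereo elements differ; a stereocentre at a saturated ring carbon is drawn R in compound 2 and S in compound 3. Among the compounds with values here, no pair of measured compounds differing only in this way is available, so the size of such a step cannot be read from the numbers in hand; the only anchor is the value of compound 2 itself. Inversion at a saturated ring carbon of a shared core of this kind is expected to be consequential rather than neutral, and the step of a 50-fold higher number from compound 2 to compound 3 (1.70 log units; beyond the scatter) is expected to run toward weaker inhibition. Compound 3 is therefore estimated to give 4 nM, within a range from 0.2 nM to 80 nM.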

Compound 3, half-maximal inhibitory concentration: 0.1 nM
Compound 3: the middle estimate sits 40-fold (1.60 log units) above what was measured, and the stated range ends above it.
By their numbers in this assay, from the lowest: compounds 2 and 3 (each within the scatter of the next); then compound 1.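

In this assay, inverting the saturated ring carbon, drawn R in compound 2 and S in compound 3, gives a 1.3-fold higher number from compound 2 to compound 3 (0.10 log units; within the scatter), so this read-out does not resolve any effect of the configuration at this position. Within the data shown here, this is the first measured pair that differs in one place, which makes it the first direct reading of a change at this stereocentre, and what separates its two members is exact: the fact that compounds 2 and 3 differ only in the configuration as drawn. The finding covers only one of the four stereo elements, and only with the side chain that carries the trifluoromethyl group.

From the compounds shown here alone, it remains open whether the same inversion would leave the number unchanged on the side chain of compound 1, which carries a methoxy group and no trifluoromethyl group, and what inversion at any of the other three stereo elements would do. The compounds shown also leave open how this pair would respond to a nitrile or a carboxylic acid in place of the trifluoromethyl group, or to a longer chain on the ring nitrogen.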